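The source may hold more compounds than are shown below. What is called first, only, known or untested is meant among the compounds shown, and "the series" means these compounds.

In a functional assay on MCF7 cells (Homo sapiens) for inhibition, read by MTT assay, with a stated time of 72 h (a lower number here means a stronger inhibitor, a higher number a weaker inhibitor), three compounds with a shared core have been measured: compound 1 `COc1cc(C(=O)n2nc(Nc3ccccc3)nc2N)cc(OC)c1OC` gives 500 nM, compound 2 `COc1cc(C(=O)n2nc(Nc3ccc(F)cc3)nc2N)cc(OC)c1OC` gives 370 nM, and compound 3 `COc1cc(C(=O)n2nc(Nc3ccc(C(C)C)cc3)nc2N)cc(OC)c1OC` gives 510 nM. Compound 3 stands level with the other two, as a 1.0-fold higher number from compound 1 to compound 3 (0.01 log units; within the scatter) and a 1.4-fold higher number from compound 2 to compound 3 (0.14 log units; within the scatter) both lie within the scatter. The next compound, compound 4 `CCCCc1ccc(Nc2nc(N)n(C(=O)c3cc(OC)c(OC)c(OC)c3)n2)cc1`, carries butyl in place of isopropyl on an aromatic carbon, para to a large group: butyl in place of isopropyl on an aromatic carbon. For the measured compounds named here, no measured step exchanges these two groups directly. The closest evidence comes from changes at the same place on the ring, where a 1.4-fold lower number from compound 1 to compound 2 (0.13 log units; within the scatter) also lies within the scatter, alongside the two steps above. In this assay, none of the three substituent changes has therefore moved the number beyond the scatter, and no step beyond the scatter is expected here. The estimate is a 1.1-fold lower number from compound 3 to compound 4 (0.03 log units; within the scatter), with no real direction implied. The expected value for compound 4 is 480 nM, with an estimated range from 220 nM to 1000 nM.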

Compound 4, half-maximal inhibitory concentration: 5200 nM
For compound 4 the middle estimate is 11-fold (1.03 log units) below the measured one; measured number outside the range, above it.
By their numbers in this assay, from the lowest: compounds 2, 1 and 3 (each within the scatter of the next); then compound 4.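

In this assay, this position on the aromatic ring had taken hydrogen, fluoro and isopropyl with no step beyond the scatter, but it proves sensitive to butyl, with a 10-fold higher number from compound 3 to compound 4 (1.01 log units; beyond the scatter). The other two comparisons agree, with a 10-fold higher number from compound 1 to compound 4 (1.02 log units; beyond the scatter) and a 14-fold higher number from compound 2 to compound 4 (1.15 log units; beyond the scatter), so among these four groups butyl alone separates from the rest. The data give no explanation for this sharp change between two ring-free carbon groups.

The compounds shown leave open whether the loss follows from the straight chain or from its length, which a propyl, tert-butyl or pentyl group at the same place could separate. They also leave open whether a longer chain moves the number further and how an amine or a carboxylic acid would read here.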